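Ring Swap on the Carbonyl Carbon: Compound 2 to Compound 3

This account rests on a few compounds, and the source may have more. Where it says the series, first, only, none or still open, it means among the compounds named here.

Compound 1 `COc1cc(-c2cc(/C=C/C(=O)c3ccc(N)cc3)[nH]n2)cc(OC)c1OC`: 56%
Compound 2 `COc1ccc(C(=O)/C=C/c2cc(-c3cc(OC)c(OC)c(OC)c3)n[nH]2)cc1`: 72%

In a functional assay on HCT-116 cells (Homo sapiens) for cytotoxicity, read by sulforhodamine B assay, with a stated time of 48 h, tested at 1 uM (on this read-out lower numbers stand for a stronger effect and higher numbers for a weaker effect at the one concentration tested), compound 2 gives 72%, the higher of the two measured numbers. Going by the values given here, the only measured step, a number 16 percentage points higher from compound 1 to compound 2 (beyond the scatter), arose from methoxy in place of amino on an aromatic carbon. Compound 3 `COc1cc(-c2cc(/C=C/C(=O)c3ccc(F)c(F)c3)[nH]n2)cc(OC)c1OC` differs from compound 2 by 3,4-difluorophenyl in place of 4-methoxyphenyl on a carbonyl carbon. That exchange touches the same aromatic ring as the measured step but replaces it entirely, so the guidance is loose. Compound 3 is expected to move a number 8 percentage points lower from compound 2 to compound 3 (within the scatter), within the scatter or slightly downward. Compound 3 is estimated at 64%, between 44% and 84%.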

Compound 3, a percentage reported as activity, at one concentration (the size of the read-out at that concentration, not a potency): 113%
Estimate against measurement, compound 3: 49 percentage points below; the measured number lies above the stated range.
By their numbers in this assay, from the lowest: compound 1; then compound 2; then compound 3.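

In this assay, the step to 3,4-difluorophenyl on the carbonyl carbon is large from either earlier group: a number 41 percentage points higher from compound 2 to compound 3 (beyond the scatter) and a number 57 percentage points higher from compound 1 to compound 3 (beyond the scatter). The earlier step had shown only a modest change at this aromatic ring, whereas these show that replacing the whole ring can weaken the effect far more. No available evidence accounts for this loss. The compounds shown leave open whether a single fluorine would give the same result as the pair. They also leave open how a hydroxyl or a carboxylic acid on this ring would read.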